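Replacement of the thiazolyl at the core with a benzylamine

This account rests on a few compounds, and the source may have more. Where it says the series, first, only, none or still open, it means among the compounds named here.

Among the measured compounds shown here, compound 1 `CCCC[S+]([O-])c1sc2nc(-c3nccs3)cc(-c3nccs3)c2c1N` carries the lowest number so far in an assay for inhibition of 15-hydroxyprostaglandin dehydrogenase [NAD(+)] (Homo sapiens), read by fluorescence, with a stated time of 15 min, in the presence of a further agent that is not named here (a higher number here means a weaker inhibitor, a lower number a stronger inhibitor), giving 1.8 nM in this assay. Compound 2 `CCC[S+]([O-])c1sc2nc(-c3nccs3)cc(C)c2c1N` differs from compound 1 in two places, so the two are not a single step, and in this assay compound 2 gives 5.3 nM, a higher number than compound 1 and beyond the scatter.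

The next compound in the series is compound 3 `CCCC[S+]([O-])c1sc2nc(-c3nccs3)cc(-c3ccc(CN)cc3)c2c1N`. It differs from compound 1 as follows: 4-(aminomethyl)phenyl in place of 1,3-thiazol-2-yl on an aromatic carbon. For the measured compounds named here, the two compounds that have been measured do not share this change, so no measured step speaks to it directly; the only thing the numbers show is that a change at this position of the core, combined with a change in the sulfinyl chain, moved compound 2 to a higher number than compound 1.

For compound 3 a moderate move to a higher number than compound 1 is expected, the step of a 2.5-fold higher number from compound 1 to compound 3 (0.40 log units; beyond the scatter) somewhat beyond the scatter, while the range kept wide enough to include a value close to compound 1. Compound 3 is estimated to give 4.5 nM in this assay, between 1 nM and 20 nM.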

Compound 3, half-maximal inhibitory concentration: 11.5 nM
For compound 3 the middle estimate is 2.6-fold (0.41 log units) below the measured one, and the stated range covers the measured number.
By their numbers in this assay, from the lowest: compound 1; then compound 2; then compound 3.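

In this assay, 4-(aminomethyl)phenyl in place of 1,3-thiazol-2-yl, on the aromatic carbon opposite the ring nitrogen, gives a 6.4-fold higher number from compound 1 to compound 3 (0.81 log units; beyond the scatter). Among the compounds shown here, this is the first step that differs in one place, so it shows that this position alone can shift the number beyond the scatter, which the two-place difference between compound 1 and compound 2 could not show. The change costs potency without abolishing it, as compound 3 still gives 11.5 nM, but no measurement at hand accounts for the size of the step.

This one step does not separate the exchange of the 1,3-thiazol-2-yl ring for a carbon-only six-membered aromatic ring from the addition of the aminomethyl group, so an unsubstituted phenyl, a 4-(hydroxymethyl)phenyl or a 4-carboxyphenyl at this carbon would be needed to tell the two apart. On these data alone, it also remains open whether the same exchange would give a step of similar size with a propylsulfinyl chain in place of the butylsulfinyl chain, or with a different group at the remaining 1,3-thiazol-2-yl position.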